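Swapping methyl for chloro on the aryl piperazine

A few compounds are considered here, and "the series" means these few. Any claim that something is new, unique, unknown or untested is made for them only; others in the source may bear on it.

Measured so far:
Compound 1, `CCC(C(=O)N1CCN(c2cccc(C)c2)CC1)N1C(=O)CCC1=O`: 100%
Compound 2, `CCC(C(=O)N1CCN(c2cccc(Cl)c2)CC1)N1C(=O)CCC1=O`: 75%
Compound 3, `Cc1cccc(N2CCN(C(=O)C(C)N3C(=O)CCC3=O)CC2)c1`: 100%

All three were tested in a functional assay on the whole organism (strain Swiss) with Mus musculus as the target, in the maximal electroshock model, with a stated time of 0.25 h, at a dose of 300 mg/kg by the intraperitoneal route; on this read-out lower numbers stand for a weaker effect and higher numbers for a stronger effect at the one dose given. Compound 1 and compound 3 sit level with each other, and compound 2 lies lower. The difference between compound 1 and compound 3 is hydrogen in place of methyl on a saturated chain carbon, two bonds along the chain from an amide-type nitrogen in a ring and a carbonyl carbon, and this gave no change at the digits printed from compound 1 to compound 3 (within the scatter). The difference between compound 1 and compound 2 is chloro in place of methyl on an aromatic carbon, and this gave a number 25 percentage points lower from compound 1 to compound 2 (beyond the scatter).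

Compound 4, `CC(C(=O)N1CCN(c2cccc(Cl)c2)CC1)N1C(=O)CCC1=O`, has not yet been measured in this assay. It differs from compound 3 by chloro in place of methyl on an aromatic carbon, the same change, at the same place, as between compound 1 and compound 2. Since compound 3 matches compound 1 and the change is the same, the expected step is a number 25 percentage points lower from compound 3 to compound 4 (beyond the scatter), resting on a number 25 percentage points lower from compound 1 to compound 2 (beyond the scatter); one earlier instance is thin ground, so the range is kept wide. Compound 4 is expected to give 75%, estimated between 50% and 100%.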

Compound 4, a percentage reported as activity, at one dose (the size of the read-out at that dose, not a potency): 75%
Compound 4: middle estimate and measured number agree at the digits printed, within the range that was stated.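

In this assay, going from 3-methylphenyl to 3-chlorophenyl gave a number 25 percentage points lower from compound 3 to compound 4 (beyond the scatter), which repeats the step seen on the other core: the same change on two cores in this assay, a number 25 percentage points lower (beyond the scatter) from compound 1 to compound 2 and a number 25 percentage points lower (beyond the scatter) from compound 3 to compound 4, 0 percentage points apart, within the scatter of two such steps

Hydrogen in place of methyl on the saturated chain carbon gave no change at the digits printed from compound 2 to compound 4 (within the scatter), and this too matches the earlier result: the same change on two cores in this assay, no change at the digits printed (within the scatter) from compound 1 to compound 3 and no change at the digits printed (within the scatter) from compound 2 to compound 4, 0 percentage points apart, within the scatter of two such steps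

Across these four compounds, then, each change behaved the same on both cores, so the effect of one change could be carried over without regard to the other; this is shown only for two pairs of compounds at one dose, however, and it says nothing about potency or about cores outside this set.

The compounds shown leave open whether another group on that aromatic carbon, such as methoxy or trifluoromethyl, would follow the chloro or the methyl compounds. They also leave open whether a longer chain on the saturated chain carbon would give the same read-out as the compounds here.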